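The source may report more compounds than this note shows. Statements on the series, on what has been measured and on what is new or still open speak of the compounds shown alone.

In a functional assay on NCI-H460 cells (Homo sapiens) for cytotoxicity, read by MTT assay, with a stated time of 72 h (on this read-out higher numbers stand for weaker inhibition and lower numbers for stronger inhibition), compound 2 `COc1cc2c(Oc3ccc(NC(=O)c4nn(-c5ccc(F)cc5)c(=O)c5ccccc45)cc3F)ccnc2cc1OCCCN1CCC(C)CC1` gives 110 nM. Among the measured compounds shown here, compound 1 `COc1cc2c(Oc3ccc(NC(=O)c4nn(-c5ccc(F)cc5)c(=O)c5ccccc45)cc3F)ccnc2cc1OCCCN1CCN(C)CC1` gives 91 nM, and the only measured step, a 1.2-fold higher number from compound 1 to compound 2 (0.08 log units; within the scatter), leaves the two indistinguishable. Compound 3 `COc1cc2c(Oc3ccc(NC(=O)c4nn(-c5ccccc5Br)c(=O)c5ccccc45)cc3F)ccnc2cc1OCCCN1CCC(C)CC1` differs from compound 2 by 2-bromophenyl in place of 4-fluorophenyl on an aromatic nitrogen. That measured step concerns the saturated chain end, not the aryl on the ring nitrogen, so it offers no guide to this change, and the data hold nothing else on that position. Compound 3 is therefore expected to land near compound 2, with an estimated step of a 1.4-fold higher number from compound 2 to compound 3 (0.13 log units; within the scatter), giving an estimate of 150 nM, ranging from 50 nM to 500 nM.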

Compound 3, half-maximal inhibitory concentration: 390 nM
For compound 3 the middle estimate is 2.6-fold (0.41 log units) below the measured one, and the stated range covers the measured number.
By their numbers in this assay, from the lowest: compounds 1 and 2 (each within the scatter of the next); then compound 3.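

Unlike the change at the saturated chain end, 2-bromophenyl in place of 4-fluorophenyl on the aromatic nitrogen goes beyond the scatter in this assay, with a 3.5-fold higher number from compound 2 to compound 3 (0.55 log units; beyond the scatter) and so weaker inhibition. The aryl on this nitrogen therefore matters to the read-out, though the step is modest. Nothing at hand accounts for the step. Because the halogen and its place on the phenyl change together, their shares cannot be separated; 4-bromophenyl or 2-fluorophenyl would separate them. As far as these compounds go, how an unsubstituted phenyl or a methyl on this nitrogen would read remains open.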